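Aryl swap on the fused ring: thiazole for pyrazole

This account rests on a few compounds, and the source may have more. Where it says the series, first, only, none or still open, it means among the compounds named here.

Measured so far in a functional assay on CHO cells for agonist activity at Alpha-1A adrenergic receptor (Homo sapiens), read by FLIPR and calcium flux; a lower number here means that less compound is needed, a higher number that more compound is needed for the effect:
compound 1 `Cc1n[nH]cc1-c1cccc2c1CCC2c1ncc[nH]1`: 3 nM
compound 2 `Cn1ccc(-c2cccc3c2CCC3c2ncc[nH]2)n1`: > 1300 nM
compound 3 `COc1cccc2c1CCC2c1ncc[nH]1`: 32 nM

Compound 1 gives 3 nM in this assay, the lowest of the two numbers measured; the nearest is compound 3, with an 11-fold higher number from compound 1 to compound 3 (1.03 log units; beyond the scatter). For compound 2 the result is only a limit of the assay, > 1300 nM, as noted in the limit of > 1300 nM in this assay, at which 1 of the 3 values shown sits. Compound 4 `c1cc(-c2nccs2)c2c(c1)C(c1ncc[nH]1)CC2`, not yet measured, differs from compound 1 by 1,3-thiazol-2-yl in place of 3-methyl-1H-pyrazol-4-yl on an aromatic carbon. Both measured departures from the 3-methyl-1H-pyrazol-4-yl group, an 11-fold higher number from compound 1 to compound 3 (1.03 log units; beyond the scatter) and an at least 430-fold higher number from compound 1 to compound 2 (2.63 log units; beyond the scatter), were large rises, so a clearly higher number is expected for this change too. Compound 4 is therefore estimated at 100 nM, with a range of 15 nM to 1000 nM, an expected step of a 33-fold higher number from compound 1 to compound 4 (1.52 log units; beyond the scatter).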

Compound 4, half-maximal effective concentration: 426 nM
Beside the measured number, compound 4's estimate is 4.3-fold (0.63 log units) below it; measured number inside the range.
By their numbers in this assay, from the lowest: compound 1; then compound 3; then compound 4. At a limit, above all of these: compound 2.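

The low number of compound 1 depends on more than a five-membered aromatic ring with 2 hetero atoms at this aromatic carbon: a 140-fold higher number from compound 1 to compound 4 (2.15 log units; beyond the scatter). The 1,3-thiazol-2-yl group also falls behind the methoxy group here: a 13-fold higher number from compound 3 to compound 4 (1.12 log units; beyond the scatter). The comparison between the two heteroaryl compounds rests on a limit of the assay and gives only a bound: an at least 3.0-fold lower number from compound 2 to compound 4 (0.48 log units; beyond the scatter).

As far as these compounds go, whether the hydrogen-bond donor lost with the 3-methyl-1H-pyrazol-4-yl group matters remains open, as the change also swaps the ring and its attachment. From the compounds shown here alone, how a primary amine or a carboxamide would read at this carbon is also open.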